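Lengthening the hydrazone side chain of compound 1

The source may hold more compounds than are shown below. What is called first, only, known or untested is meant among the compounds shown, and "the series" means these compounds.

Measured compounds in a functional assay, with a stated time of 90 min; a higher number here means that more compound is needed for the effect, a lower number that less compound is needed:
compound 1 `CCC/C(C)=N\Nc1nc(-c2cccc([N+](=O)[O-])c2)cs1` gives 1200000 nM
compound 2 `CCC(CC)=NNc1nc(-c2cccc([N+](=O)[O-])c2)cs1` gives 1100000 nM
compound 3 `CCCCC/C(CC)=N\Nc1nc(-c2cccc([N+](=O)[O-])c2)cs1` gives 1470000 nM

Compound 1 stands second highest of the three numbers in this assay. Its nearest neighbour is compound 2, separated by a 1.1-fold lower number from compound 1 to compound 2 (0.04 log units; within the scatter), and its furthest is compound 3, from which it differs by a gap that is also within the scatter. All three values therefore sit together.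

The unmeasured compound 4 `CCCCCC/C(C)=N\Nc1nc(-c2cccc([N+](=O)[O-])c2)cs1` differs from compound 1 by propyl in place of hydrogen on a saturated chain carbon, three bonds along the chain from a carbon with a double bond to nitrogen. The closest measured precedent is the step from compound 2 to compound 3, in which a propyl group also replaces a hydrogen on the saturated chain, two bonds along from the carbon with a double bond to nitrogen; that step gave a 1.3-fold higher number from compound 2 to compound 3 (0.13 log units; within the scatter). The exchange of one six-atom group for another, a 1.1-fold lower number from compound 1 to compound 2 (0.04 log units; within the scatter), likewise moved nothing beyond the scatter. On this basis, no step beyond the scatter is expected in this assay for compound 4, in either direction; the expected step is a 1.1-fold higher number from compound 1 to compound 4 (0.05 log units; within the scatter). Compound 4 is accordingly estimated at 1350000 nM, with a range from 700000 nM to 2700000 nM.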

Compound 4, half-maximal effective concentration: 1240000 nM
Beside the measured number, compound 4's estimate is 1.1-fold (0.04 log units) above it; the measured number falls inside the stated range.
By their numbers in this assay, from the lowest: compounds 2, 1, 4 and 3 (each within the scatter of the next).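

In this assay, propyl in place of hydrogen on a saturated chain carbon, three bonds along the chain from a carbon with a double bond to nitrogen, gives a 1.0-fold higher number from compound 1 to compound 4 (0.01 log units; within the scatter). The earlier compounds had shown this change only two bonds along the chain, in compound 3; compound 4 now shows that the position three bonds along also takes the step from propyl to hexyl with no move beyond the scatter. The same change has thus been read on two cores, and the two readings agree: the same change on two cores in this assay, a 1.3-fold higher number (0.13 log units; within the scatter) from compound 2 to compound 3 and a 1.0-fold higher number (0.01 log units; within the scatter) from compound 1 to compound 4, 1.3-fold (0.11 log units) apart, within the scatter of two such steps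

The compounds shown carry only saturated carbon chains in this part of the molecule, so it stays open whether a carboxylic acid, an amine or a hydroxyl group in place of the propyl would give a step beyond the scatter in this assay. Also open is whether a chain longer than hexyl would do so, and, with every step shown so far lying within the scatter, which part of these molecules this number responds to at all.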